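The source may hold more compounds than are shown below. What is called first, only, known or untested is meant among the compounds shown, and "the series" means these compounds.

Working notes on the series, read in a functional assay on Jurkat cells (Homo sapiens) for antiproliferative activity, read by MTT assay, with a stated time of 72 h; a lower number here means a stronger inhibitor, a higher number a weaker inhibitor. Compound 3 `COc1cc(-c2ncnn2-c2ccccc2)cc(OC)c1OC` carries an unsubstituted phenyl on the shared core. Compound 3 gives > 10000 nM, which is a limit and not a number. Compound 1 `COc1cc(-c2ncnn2-c2ccc(N)cc2)cc(OC)c1OC` gives > 10000 nM, also a limit. Compound 2 `COc1cc(-c2ncnn2-c2ccc(Cl)cc2)cc(OC)c1OC` gives > 10000 nM, again a limit. The whole measured set stands at one ceiling, (the limit of > 10000 nM in this assay, at which 3 of the 3 values shown sit), so compound 3 has no numeric place in the series.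

Compound 4 `COc1ccc(-n2ncnc2-c2cc(OC)c(OC)c(OC)c2)cc1` follows from compound 3 by methoxy in place of hydrogen on an aromatic carbon, phenyl to 4-methoxyphenyl. The measured steps that bear on this change are a step that the two limits leave unreadable from compound 1 to compound 3, a step that the two limits leave unreadable from compound 2 to compound 3 and a step that the two limits leave unreadable from compound 1 to compound 2. None of them has a readable size, so they support neither a size nor a direction. The estimated step of a number no higher from compound 3 to compound 4 (the limit leaves the size open) is accordingly expected to show no firm change, and another limit is the likeliest report. The expected value for compound 4 is 10000 nM, with an estimated range of 1000 nM to 30000 nM.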

Compound 4, half-maximal inhibitory concentration: 93 nM
Compound 4: middle estimate off by 110-fold (2.03 log units), on the high side; measured number outside the range, below it.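

In this assay, methoxy in place of hydrogen gives an at least 100-fold lower number from compound 3 to compound 4 (2.03 log units; beyond the scatter). Methoxy in place of chloro gives an at least 100-fold lower number from compound 2 to compound 4 (2.03 log units; beyond the scatter), and methoxy in place of amino gives an at least 100-fold lower number from compound 1 to compound 4 (2.03 log units; beyond the scatter), so among these four compounds, only methoxy on this aromatic carbon, para to a large group, brings a numeric value. The steps among compound 1, compound 2 and compound 3 cannot be read, as all three rest on one limit: the limit of > 10000 nM in this assay, at which 3 of the 4 values shown sit.

Going by these compounds, whether this result is particular to methoxy stays open, and ethoxy, hydroxy or methylthio at the same place would bear on that. On these data alone, how far compound 1, compound 2 and compound 3 lie past their limits is also open, so the full size of the three steps remains unknown.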